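From Amino to Trifluoromethyl: Where Compound 3 May Land

A few compounds are considered here, and "the series" means these few. Any claim that something is new, unique, unknown or untested is made for them only; others in the source may bear on it.

compound 1 `CN(C)C(=S)n1ncnc1N` — in a functional assay on the whole organism for inhibition, with Rattus norvegicus as the target, at a dose of 30 mg/kg (on this read-out higher numbers stand for more inhibition at the one dose given (going by the name of the read-out) and lower numbers for less inhibition), compound 1 gives 34%
compound 2 `C/N=C(\S)n1nc(-c2ccc(N)cc2)nc1N` — in this assay compound 2 has no result reported

Compound 2 therefore stands without a number in this assay, and nothing can be said of how it compares with compound 1. Compound 3 `C/N=C(\S)n1nc(-c2ccc(C(F)(F)F)cc2)nc1N` differs from compound 2 in a single place: trifluoromethyl in place of amino on an aromatic carbon. For the measured compounds named here, no step between measured compounds is available, so the size of the step in this assay cannot be read from any pair; on the evidence at hand one expects no step beyond the scatter in either direction, while allowing that a real step could hide behind the missing value of compound 2. Compound 3 is expected to give about 30% in this assay, with a range from 5% to 60%. Compound 2 has no number, so this estimate rests on compound 1 alone, which gives 34%.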

Compound 3, a percentage reported as inhibition, in the whole organism at one dose (the size of the read-out at that dose, not a potency): 91%
Estimate against measurement, compound 3: 61 percentage points below; the measured number lies above the stated range.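

In this assay, for the compounds shown here, compound 3 gives 91% while compound 2 shows no value, so no step between the two can be read. As far as these compounds go, whether trifluoromethyl in place of amino changes inhibition at all stays open. Nothing shown here bears on the result.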